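Replacing 2-chloropyridin-3-yl with pyridin-4-yl in compound 3

The source may hold more compounds than are shown below. What is called first, only, known or untested is meant among the compounds shown, and "the series" means these compounds.

Measured in an ADME assay on HEK-293T cells (Homo sapiens) for cytotoxicity, read by MTT assay, with a stated time of 48 h; a lower number here means that less compound is tolerated, a higher number that more compound is tolerated:
Compound 1 `Cn1cc(C2CC(c3ccccc3)=NN2C(=O)c2cccnc2)c2ccccc21`: > 300000 nM
Compound 2 `COc1ccc(C(=O)N2N=C(c3ccccc3)CC2c2cn(C)c3ccccc23)cn1`: > 300000 nM
Compound 3 `Cn1cc(C2CC(c3ccccc3)=NN2C(=O)c2cccnc2Cl)c2ccccc21`: > 300000 nM

None of these three entries is a number, since each one is a limit of the assay. The same holds across the whole set, which shows (the limit of > 300000 nM in this assay, at which 3 of the 3 values shown sit). Compound 3 therefore has no numerical position, and its > 300000 nM is a limit.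

The next compound is compound 4 `Cn1cc(C2CC(c3ccccc3)=NN2C(=O)c2ccncc2)c2ccccc21`, which carries pyridin-4-yl in place of 2-chloropyridin-3-yl on a carbonyl carbon.

For the measured compounds named here, three measured steps bear on this change at the same group. They are a step that the two limits leave unreadable from compound 1 to compound 3, a step that the two limits leave unreadable from compound 2 to compound 3 and a step that the two limits leave unreadable from compound 1 to compound 2. None of them has a size that can be read, so they offer no measured effect to carry over. They do show that these changes on the carbonyl-bound ring left each compound at the limit in this assay.

No step beyond the scatter is therefore expected, in either direction. The expected change is a number no higher from compound 3 to compound 4 (the limit leaves the size open), an estimate with no measured size behind it. Another limit is the likeliest report. For compound 4 the estimated value is 300000 nM, with an expected range from 120000 nM to 500000 nM.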

Compound 4, half-maximal cytotoxic concentration: 97300 nM
Estimate against measurement, compound 4: 3.1-fold (0.49 log units) above; measured number below the stated range.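

In this assay the ring on the carbonyl carbon now gives the only readable number among the compounds shown: compound 4, with pyridin-4-yl at this place, gives 97300 nM, which is an at least 3.0-fold lower number from compound 3 to compound 4 (0.48 log units; beyond the scatter). For the compounds shown here, the change reads the same way against the other two compounds, as an at least 3.0-fold lower number from compound 2 to compound 4 (0.48 log units; beyond the scatter) and as an at least 3.0-fold lower number from compound 1 to compound 4 (0.48 log units; beyond the scatter), the last of these being pyridin-4-yl in place of pyridin-3-yl, so this place can affect how much compound the cells tolerate, which the earlier compounds could not show. Compound 1, compound 2 and compound 3 all remain limits rather than numbers, so these three steps give only a minimum size: the limit of > 300000 nM in this assay, at which 3 of the 4 values shown sit.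

The steps among compound 1, compound 2 and compound 3 cannot be read, which leaves the order of those three open, along with how large the steps to compound 4 really are. On these data alone, it also stays open whether a lower number would follow with other groups on the same carbonyl carbon, such as a plain phenyl ring or a morpholine, or is confined to pyridin-4-yl.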